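Compound 3 to compound 4: losing the aryl group

The source may hold more compounds than are shown below. What is called first, only, known or untested is meant among the compounds shown, and "the series" means these compounds.

Among the measured compounds shown here, in a functional assay on SW-620 cells (Homo sapiens) for antiproliferative activity, read by MTT assay, with a stated time of 72 h (on this read-out lower numbers stand for stronger inhibition and higher numbers for weaker inhibition), compound 1 (`CCCCCc1ccc(-c2cn(C[C@H](O)[C@H]3OC(=O)C(OCc4ccccc4)=C3OCc3ccccc3)nn2)cc1`) gives 12200 nM, the only number in the set. Compound 2 (`Cc1ccc(-c2cn(C[C@H](O)[C@H]3OC(=O)C(OCc4ccccc4)=C3OCc3ccccc3)nn2)cc1`) reads > 100000 nM, which is a limit. Compound 3 (`O=C1O[C@H]([C@@H](O)Cn2cc(-c3cc(F)cc(F)c3)nn2)C(OCc2ccccc2)=C1OCc1ccccc1`) reads > 100000 nM, also a limit. Compound 4 (`O=C1O[C@H]([C@@H](O)Cn2ccnn2)C(OCc2ccccc2)=C1OCc1ccccc1`) carries hydrogen in place of 3,5-difluorophenyl on an aromatic carbon. For the measured compounds named here, no measured step removes this aryl group outright. The nearest evidence is an at least 8.1-fold higher number from compound 1 to compound 2 (0.91 log units; beyond the scatter) and an at least 8.1-fold higher number from compound 1 to compound 3 (0.91 log units; beyond the scatter), both beyond the scatter, while a step that the two limits leave unreadable from compound 2 to compound 3 cannot be sized. Recovery of a readable value is therefore not expected, given that compound 1 alone shows one at 12200 nM. The estimated step is a step that the limit leaves unreadable from compound 3 to compound 4, probably unreadable again. For compound 4 the expected value is 150000 nM, with an estimated range of 50000 nM to 400000 nM.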

Compound 4, half-maximal inhibitory concentration: > 100000 nM
Compound 4 was reported as a limit; the forecaster's own chance of this, stated with the estimate: 85%; the middle value is on the limit's open side.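

In this assay compound 4 gives > 100000 nM as a limit. Hydrogen on this aromatic carbon gives an at least 8.1-fold higher number from compound 1 to compound 4 (0.91 log units; beyond the scatter) and no readable value, so removing the aryl group outright does not bring one back, and among the compounds shown only the 4-pentylphenyl group gives one. The steps among compound 2, compound 3 and compound 4 cannot be read, because all three stand at the same limit: the limit of > 100000 nM in this assay, at which 3 of the 4 values shown sit.

On these data alone, whether a butyl or a hexyl chain in place of the pentyl chain keeps a readable value stays open. So does the effect of an amine on this aromatic carbon.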